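The compounds below may be only part of what the source reports. "The series", "measured", "known", "first", "only" and "open" are said of these compounds alone.

Measured so far:
compound 1, `Cc1ccc(C(=O)c2cc(C)ccc2OC(=O)c2ccc(Cl)cc2)cc1`: 57.3 mg/kg
compound 2, `Cc1ccc(C(=O)Oc2ccc(F)cc2C(=O)c2ccc(C)cc2)cc1`: 70.1 mg/kg

Both compounds were run in a functional assay on the whole organism (strain Albino) for inhibition, with Rattus norvegicus as the target, read by paw edema; on this read-out lower numbers stand for an effect already at smaller amounts and higher numbers for an effect only at larger amounts of compound. Compound 1 gives 57.3 mg/kg and compound 2 gives 70.1 mg/kg in this assay; the two numbers lie within the usual scatter of each other, so compound 2 cannot be set apart from compound 1 on these data. Among the compounds with values here, no step between compounds differing in a single place is available, so there is no measured step to lean on.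

The next compound, compound 3, `Cc1ccc(C(=O)c2cc(F)ccc2OC(=O)c2ccc(Cl)cc2)cc1`, is not yet measured. It differs from compound 2 by chloro in place of methyl on an aromatic carbon. Compound 1 carries the same chloro on the same ring, paired with a different group on the other ring, and its value of 57.3 mg/kg sits close to that of compound 2. On that basis the step of a 1.2-fold lower number from compound 2 to compound 3 (0.07 log units; within the scatter) is expected to be none beyond the scatter. Compound 3 is therefore estimated at 60 mg/kg in this assay. Its range is expected to run from 35 mg/kg to 105 mg/kg.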

Compound 3, dose for half-maximal effect: 76.2 mg/kg
Compound 3: middle estimate off by 1.3-fold (0.10 log units), on the low side; the range from low to high includes it.
By their numbers in this assay, from the lowest: compounds 1, 2 and 3 (each within the scatter of the next).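

In this assay, the change from 4-methylphenyl to 4-chlorophenyl, on an aromatic carbon para to a large group, gives a 1.1-fold higher number from compound 2 to compound 3 (0.04 log units; within the scatter), so chloro and methyl cannot be told apart at this position on this read-out. The other single change gives a 1.3-fold higher number from compound 1 to compound 3 (0.12 log units; within the scatter), so fluoro and methyl cannot be told apart at that second site either, and both sites have now been varied on the shared core without a step beyond the scatter. Nothing measured here speaks to the reason for this flat reading.

Still open, from the compounds shown here alone, is whether a group of another kind, such as an amine, a carboxylic acid, methoxy or a longer chain such as butyl, para to a large group would move the number beyond the scatter, or whether this position stays equally flat. Also open, going by these compounds, is how the core carrying methyl at both sites would read, which would show whether the two exchanges behave independently of each other.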